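A few compounds are considered here, and "the series" means these few. Any claim that something is new, unique, unknown or untested is made for them only; others in the source may bear on it.

In an ADME assay on HepG2 2.2.15 cells (Homo sapiens) for cytotoxicity (on this read-out lower numbers stand for higher toxicity in this test and higher numbers for lower toxicity in this test), compound 1 (`C=CCn1c(=O)c(CCO)c(-c2ccccc2Cl)c2cc(Cl)ccc21`) gives 23000 nM and compound 2 (`CC(=O)OCCc1c(-c2ccccc2Cl)c2cc(Cl)ccc2[nH]c1=O`) gives 27000 nM on the same read-out. These two numbers lie within the usual scatter of repeated measurements, so compound 2 stands level with compound 1 and neither can be ranked above the other. The two compounds differ in more than one place, so their values do not show the effect of any single structural change.

Compound 3 (`CCCC(=O)OCCc1c(-c2ccccc2Cl)c2cc(Cl)ccc2[nH]c1=O`) differs from compound 2 in just one place (ethyl in place of hydrogen on a saturated chain carbon bound to a carbonyl carbon), with ethyl in place of hydrogen on a saturated chain carbon bound to a carbonyl carbon. Put another way, acetoxy becomes (propylcarbonyl)oxy while the rest of the molecule stays the same. Within the data shown here, no measured pair shows what this particular change does, so the forecast has little to rest on beyond the two close values. No shift beyond the scatter is expected in this assay in either direction. The expected size of a 1.1-fold lower number from compound 2 to compound 3 (0.03 log units; within the scatter) is therefore small. For compound 3 the estimated value is 25000 nM with an expected range from 12000 nM to 50000 nM in this test.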

Compound 3, half-maximal cytotoxic concentration: 52000 nM
The estimate for compound 3 lay 2.1-fold (0.32 log units) below the measured number; the whole stated range lies below it.
By their numbers in this assay, from the lowest: compounds 1, 2 and 3 (each within the scatter of the next, the first and the last beyond it).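

Replacing hydrogen with ethyl on a saturated chain carbon bound to a carbonyl carbon turns the acetoxy group into (propylcarbonyl)oxy, and in this assay this gives a 1.9-fold higher number from compound 2 to compound 3 (0.28 log units; within the scatter), the first single-place step available for this position. Since that step lies within the usual scatter of repeated measurements, compound 2 and compound 3 cannot be ranked against each other, and this one change shows no real effect on the read-out. The result therefore says only that adding these two carbons at this place leaves the number indistinguishable from that of compound 2, and nothing measured here offers an explanation for the size of the step.

As far as these compounds go, one step with two compounds cannot show a trend, so it remains open whether a longer chain, such as hexyl, at this same place would shift the number beyond the scatter. From the compounds shown here alone, it is equally open whether a group of a different kind there, such as an amine or a carboxylic acid, would give a value that could be told apart from those of compound 2 and compound 3.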